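Same atoms, joined differently: compound 2 to compound 4

This account rests on a few compounds, and the source may have more. Where it says the series, first, only, none or still open, it means among the compounds named here.

In a functional assay on MV4-11 cells (Homo sapiens) for antiproliferative activity, read by resazurin assay, with a stated time of 72 h (a lower number here means a stronger inhibitor of growth, a higher number a weaker inhibitor of growth), three compounds have been measured so far:
compound 1 `CC(=O)N1CCN(c2ccc(Nc3nccc(-c4c[nH]c5ccccc45)n3)cc2)CC1` gives 33 nM
compound 2 `CC(=O)N1CCN(c2ccc(Nc3nccc(-c4nn(C)c5ccccc45)n3)cc2)CC1` gives 181 nM
compound 3 `CC(=O)N1CCCN(c2cccc(Nc3nccc(-c4c[nH]c5cccnc45)n3)c2)CC1` gives 688 nM

Compound 2 holds the middle place, with a lower number for compound 1 and a higher number for compound 3. Compound 4 `CC(=O)N1CCN(c2ccc(Nc3nccc(-c4cn(C)c5ncccc45)n3)cc2)CC1` has the same atoms as compound 2, joined differently, and the change falls on an aromatic carbon (a group of 10 heavy atoms (8 carbon, 2 nitrogen; one five-membered aromatic ring with 1 hetero atom, one six-membered aromatic ring with 1 hetero atom) in place of a group of 10 heavy atoms (8 carbon, 2 nitrogen; one five-membered aromatic ring with 2 hetero atoms, one six-membered aromatic ring of carbon only), on an aromatic carbon). Within the data shown here, the only measured step at this place is a swap of a different kind (a 5.5-fold higher number from compound 1 to compound 2 (0.74 log units; beyond the scatter)), so it offers only a rough scale. Compound 3 differs from compound 2 in more than one place and adds little. A smaller step is therefore expected in this assay, within the scatter and leaning towards a higher number (a 1.5-fold higher number from compound 2 to compound 4 (0.19 log units; within the scatter)). Compound 4 is estimated at 280 nM (range 90 nM to 850 nM).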

Compound 4, concentration for 50% growth inhibition: 74 nM
Beside the measured number, compound 4's estimate is 3.8-fold (0.58 log units) above it; measured number below the stated range.
By their numbers in this assay, from the lowest: compound 1; then compound 4; then compound 2; then compound 3.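

Joining the same atoms differently in this group is enough to shift the result in this assay, with a 2.4-fold lower number from compound 2 to compound 4 (0.39 log units; beyond the scatter), so the count of atoms in the group does not alone set the number. The new group still does not match the 1H-indol-3-yl of compound 1, with a 2.2-fold higher number from compound 1 to compound 4 (0.35 log units; beyond the scatter). Nothing available here explains the effect of either change.

As far as these compounds go, it remains open whether an ethyl group or a longer chain in place of the methyl, or an amine on the six-membered ring of the new group, would lower or raise the number.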